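The source may hold more compounds than are shown below. What is called first, only, known or untested is meant among the compounds shown, and "the series" means these compounds.

Compound 1, `O=C(/C=C/c1cccc(OCc2ccccc2)c1)c1ccc([N+](=O)[O-])cc1`, gives 82400 nM in an ADME assay on CHO cells (Cricetulus griseus) for cytotoxicity, read by MTT assay, with a stated time of 68 h; a higher number here means a weaker inhibitor, a lower number a stronger inhibitor.
Compound 2, `O=C(/C=C/c1cccc(OCc2ccccc2)c1)c1ccc(Cl)cc1Cl`, gives 27500 nM in this assay.

These two compounds share a core and differ only in the ring attached to the carbonyl carbon. The change of 2,4-dichlorophenyl in place of 4-nitrophenyl on that carbon gave a 3.0-fold lower number from compound 1 to compound 2 (0.48 log units; beyond the scatter). Of the two numbers available, compound 2 holds the lower one, with compound 1 standing a step higher.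

Compound 3, `COc1ccc(C(=O)/C=C/c2cccc(OCc3ccccc3)c2)cc1`, is not yet measured. It differs from compound 2 at the same carbonyl carbon: 4-methoxyphenyl in place of 2,4-dichlorophenyl on a carbonyl carbon. For the measured compounds named here, no measured step involves a methoxy-bearing ring, so the only guide is the single step from compound 1 to compound 2, which shows that swapping the ring on the carbonyl carbon can move the number by a modest amount. For compound 3, the expectation is a modest rise from the number of compound 2, placed as a 1.8-fold higher number from compound 2 to compound 3 (0.26 log units; within the scatter), with wide uncertainty. The estimated value for compound 3 is 50000 nM, expected to fall between 20000 nM and 130000 nM.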

Compound 3, half-maximal inhibitory concentration: 22900 nM
Beside the measured number, compound 3's estimate is 2.2-fold (0.34 log units) above it; the range from low to high includes it.
By their numbers in this assay, from the lowest: compounds 3 and 2 (each within the scatter of the next); then compound 1.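

Swapping the 2,4-dichlorophenyl on the carbonyl carbon for 4-methoxyphenyl gives a 1.2-fold lower number from compound 2 to compound 3 (0.08 log units; within the scatter), so this assay cannot tell these two rings apart, even though one carries chlorine and the other a methoxy group. The second comparison, a 3.6-fold lower number from compound 1 to compound 3 (0.56 log units; beyond the scatter), replaces only the nitro group on an aromatic carbon with methoxy, and it joins a 3.0-fold lower number from compound 1 to compound 2 (0.48 log units; beyond the scatter) in setting compound 1 apart from the other two. Among these three compounds, then, two quite different rings give numbers within the scatter of each other, while the 4-nitrophenyl compound stands higher, but nothing available explains this difference.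

Three rings are too few to show whether compound 1 is the exception or whether the ring on this carbon has a broader influence on the number. A ring carrying an amine or a carboxylic acid in place of the methoxy group would test this, by showing whether such a compound falls with compound 2 and compound 3 or with compound 1.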